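A Carbamoylpiperidine in Place of the Pyrrolidine

This account rests on a few compounds, and the source may have more. Where it says the series, first, only, none or still open, it means among the compounds named here.

Compound 2 `O=C(CN1CCCC1)N1N=C(c2cc3ccccc3oc2=O)CC1c1ccccc1` gives 50200 nM in a functional assay on PC-3 cells (Homo sapiens) for cytotoxicity, read by MTT assay, with a stated time of 48 h (on this read-out higher numbers stand for weaker inhibition and lower numbers for stronger inhibition), the highest of the two numbers measured, while compound 1 `CC(C)(C)NCC(=O)N1N=C(c2cc3ccccc3oc2=O)CC1c1ccccc1` gives 16400 nM. For the measured compounds named here, the only measured step on the saturated chain carbon bound to a carbonyl carbon is a 3.1-fold higher number from compound 1 to compound 2 (0.49 log units; beyond the scatter). Compound 3 `NC(=O)C1CCN(CC(=O)N2N=C(c3cc4ccccc4oc3=O)CC2c2ccccc2)CC1` differs from compound 2 by 4-carbamoylpiperidin-1-yl in place of pyrrolidin-1-yl on a saturated chain carbon bound to a carbonyl carbon. Going by the values given here, no measured step covers this exchange, and the single change at this place was modest, so a modest shift in either direction, possibly none beyond the scatter, is expected in this assay. Compound 3 is therefore estimated at 40000 nM, within 15000 nM to 110000 nM, an expected step of a 1.3-fold lower number from compound 2 to compound 3 (0.10 log units; within the scatter).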

Compound 3, half-maximal inhibitory concentration: 8310 nM
Estimate against measurement, compound 3: 4.8-fold (0.68 log units) above, outside the stated range (below it).
By their numbers in this assay, from the lowest: compounds 3 and 1 (each within the scatter of the next); then compound 2.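

At this place on a saturated chain carbon bound to a carbonyl carbon, the number can fall as well as rise: in this assay there is a 6.0-fold lower number from compound 2 to compound 3 (0.78 log units; beyond the scatter) with 4-carbamoylpiperidin-1-yl in place of pyrrolidin-1-yl. Against (tert-butyl)amino, the same group gives a 2.0-fold lower number from compound 1 to compound 3 (0.30 log units; within the scatter) and so leaves those two compounds level, with pyrrolidin-1-yl alone apart from both. No evidence accounts for these differences. The compounds shown leave open whether the carbamoyl group or the six-membered ring carries the step, which a plain piperidin-1-yl at this place could separate.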